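Chloro substitution on two cores: cytotoxicity notes

A few compounds are considered here, and "the series" means these few. Any claim that something is new, unique, unknown or untested is made for them only; others in the source may bear on it.

Measured in an ADME assay on MT4 cells (Homo sapiens) for cytotoxicity; on this read-out higher numbers stand for lower toxicity in this test and lower numbers for higher toxicity in this test:
compound 1 `Cc1cc(C)cc(S(=O)(=O)n2c(=S)[nH]c3ccccc32)c1`: 41000 nM
compound 2 `Cc1cc(C)cc(S(=O)(=O)n2c(=S)[nH]c3ccc(Cl)cc32)c1`: 93100 nM
compound 3 `Cc1cc(C)cc(S(=O)(=O)n2c(SCC(=O)Nc3ccccc3Cl)nc3ccccc32)c1`: 107000 nM

Compound 1 and compound 2 share a core and differ only by chloro in place of hydrogen on an aromatic carbon. In this assay this yields a 2.3-fold higher number from compound 1 to compound 2 (0.36 log units; beyond the scatter). Compound 3 carries a different core; the difference between the core of compound 1 and the core of compound 3 is not broken down here. In this assay the numbers of compound 2 and compound 3 lie within the scatter of each other, while the gap from compound 1 to compound 3 is beyond the scatter.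

Compound 4 `Cc1cc(C)cc(S(=O)(=O)n2c(SCC(=O)Nc3ccccc3Cl)nc3ccc(Cl)cc32)c1` is not yet measured. It differs from compound 3 by chloro in place of hydrogen on an aromatic carbon, the same change as from compound 1 to compound 2, at the same place. The expectation rests on that one earlier pair: because a 2.3-fold higher number from compound 1 to compound 2 (0.36 log units; beyond the scatter) was seen with this change on the other core, a step of a 1.9-fold higher number from compound 3 to compound 4 (0.27 log units; within the scatter) is expected here, with little weight since it rests on a single pair. The estimate for compound 4 in this assay is 200000 nM, between 100000 nM and 400000 nM. A number this high may come back as a limit rather than a value.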

Compound 4, half-maximal cytotoxic concentration: 99300 nM
Compound 4: the middle estimate sits 2.0-fold (0.30 log units) above what was measured; measured number below the stated range.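

In this assay, chloro in place of hydrogen on an aromatic carbon gives a 1.1-fold lower number from compound 3 to compound 4 (0.03 log units; within the scatter), so on the core of compound 3 this change produces no step beyond the scatter, unlike on the core of compound 1. Set side by side, the two steps cannot be told apart: the same change on two cores in this assay, a 2.3-fold higher number (0.36 log units; beyond the scatter) from compound 1 to compound 2 and a 1.1-fold lower number (0.03 log units; within the scatter) from compound 3 to compound 4, 2.4-fold (0.39 log units) apart, within the scatter of two such steps. The two pairs therefore do not show that the outcome of this change depends on the core, nor do they show that it carries over unchanged, and one pair per core supports no rule for the series.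

The compounds shown leave open whether another group at this place, such as fluoro, methoxy or an amine, would give steps like those of chloro on either core. Also open, going by these compounds, is whether the chloro step would read the same if the chain of compound 3 ended in a carboxylic acid rather than its amide.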